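The source may report more compounds than this note shows. Statements on the series, on what has been measured and on what is new or still open speak of the compounds shown alone.

Three compounds built on a shared core were examined in a functional assay on K-562R cells (Homo sapiens) for cytotoxicity, read by XTT assay, with a stated time of 24 h; on this read-out lower numbers stand for stronger inhibition and higher numbers for weaker inhibition. Compound 1 `Cc1ccc(NC(=O)c2ccc(Br)cc2OCCCCn2ccnc2)cc1Nc1nccc(-c2cccnc2)n1` gives 44600 nM in this assay, compound 2 `Cc1ccc(NC(=O)c2cccc(OCCCCn3ccnc3)c2)cc1Nc1nccc(-c2cccnc2)n1` gives 63400 nM, and compound 3 `Cc1ccc(NC(=O)c2ccccc2OCCCCn2ccnc2)cc1Nc1nccc(-c2cccnc2)n1` gives 83400 nM. The difference between the cores of compound 2 and compound 3 is not broken down here. From compound 3 to compound 1 the change is bromo in place of hydrogen on an aromatic carbon and it was accompanied by a 1.9-fold lower number from compound 3 to compound 1 (0.27 log units; within the scatter). Compound 4 `Cc1ccc(NC(=O)c2cc(Br)cc(OCCCCn3ccnc3)c2)cc1Nc1nccc(-c2cccnc2)n1` has not yet been measured. It differs from compound 2 by bromo in place of hydrogen on an aromatic carbon, the same kind of change as that from compound 3 to compound 1, though here the bromo sits meta to a large group rather than para to a large group. Given the step of a 1.9-fold lower number from compound 3 to compound 1 (0.27 log units; within the scatter), compound 4 is expected to show a comparable step, a 1.6-fold lower number from compound 2 to compound 4 (0.20 log units; within the scatter), in this assay. Compound 4 is therefore estimated at 40000 nM, between 15000 nM and 100000 nM.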

Compound 4, half-maximal inhibitory concentration: 19100 nM
Compound 4: middle estimate off by 2.1-fold (0.32 log units), on the high side; low and high end bracket the measured number.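

In this assay, bromo in place of hydrogen on an aromatic carbon, here meta to a 4-(1H-imidazol-1-yl)butoxy group, gave a 3.3-fold lower number from compound 2 to compound 4 (0.52 log units; beyond the scatter). Set beside the earlier step on the other core, the two sizes do not differ: the same change on two cores in this assay, a 1.9-fold lower number (0.27 log units; within the scatter) from compound 3 to compound 1 and a 3.3-fold lower number (0.52 log units; beyond the scatter) from compound 2 to compound 4, 1.8-fold (0.25 log units) apart, within the scatter of two such steps. Among these compounds, the change thus carried over between these two cores with the number falling both times, but this rests on only two pairs, one of them within the scatter, and it shows nothing about other cores or other assays.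

The compounds shown leave open whether chloro or methoxy in place of the bromo would give a like step. They also leave open what a shorter chain than the 4-(1H-imidazol-1-yl)butoxy group would do.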